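One Amide Change Tested on Two Cores

The compounds below may be only part of what the source reports. "The series", "measured", "known", "first", "only" and "open" are said of these compounds alone.

Compound 1 `CC(NC(=O)C#Cc1ccc(NC(=O)Nc2ccc(Cl)c(C(F)(F)F)c2)cc1)c1ccccc1` gives 16800 nM in a functional assay on A-375 cells (Homo sapiens) for inhibition, read by MTT assay, with a stated time of 120 h; a higher number here means a weaker inhibitor, a lower number a stronger inhibitor.
Compound 2 `CNC(=O)/C=C(\C)c1ccc(NC(=O)Nc2ccc(Cl)c(C(F)(F)F)c2)cc1` reaches only the limit of this assay, > 50000 nM.
Compound 3 `CNC(=O)C#Cc1ccc(NC(=O)Nc2ccc(Cl)c(C(F)(F)F)c2)cc1` likewise sits at the limit of this assay, > 50000 nM.

Among the measured compounds shown here, the one readable step is an at least 2.9-fold lower number from compound 3 to compound 1 (0.47 log units; beyond the scatter), and the change behind it is 1-phenylethyl in place of methyl on an amide-type nitrogen. Compound 2 and compound 3 share everything except the core, where the difference is 1-methyl-2-(methylcarbamoyl)ethenyl in place of 2-(methylcarbamoyl)ethynyl on an aromatic carbon; the step between them, a step that the two limits leave unreadable from compound 2 to compound 3, cannot be sized because both values sit at the limit of > 50000 nM in this assay, at which 2 of the 3 values shown sit. Compound 4 `C/C(=C\C(=O)NC(C)c1ccccc1)c1ccc(NC(=O)Nc2ccc(Cl)c(C(F)(F)F)c2)cc1` is compound 2 carrying the same change, (1-phenylethyl in place of methyl on an amide-type nitrogen), at a place described in the same words as for compound 1.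

Because compound 2 rests at the limit of > 50000 nM in this assay, at which 2 of the 3 values shown sit, the step from compound 2 to compound 4 can only be judged from the other core: the expected step is an at least 1.6-fold lower number from compound 2 to compound 4 (0.22 log units; that floor lies within the scatter), at least a modest lowering, in line with an at least 2.9-fold lower number from compound 3 to compound 1 (0.47 log units; beyond the scatter). Compound 4 is thus estimated at 30000 nM in this assay, with a likely range from 8000 nM to 60000 nM, and a fair chance that only a limit is reported again.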

Compound 4, half-maximal inhibitory concentration: > 50000 nM
Compound 4: only a limit was reported; the forecaster's own chance of this, stated with the estimate: 45%; at least 1.6-fold (0.22 log units) between middle value and limit.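

In this assay compound 4 gives > 50000 nM as a limit and not a number. Among the compounds shown here, no step from compound 2 to compound 4 can be read, because both compounds rest at the same limit: (the limit of > 50000 nM in this assay, at which 3 of the 4 values shown sit). The compounds shown leave open whether 1-phenylethyl in place of methyl on an amide-type nitrogen lowers the number on the core of compound 2, as it does on the core of compound 1.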